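The source may hold more compounds than are shown below. What is called first, only, known or untested is meant among the compounds shown, and "the series" means these compounds.

Compound 1 `COc1cc(CNC(=O)CCCCCCC(C)C)ccc1OCCCCOc1ccc(C(N)=S)cc1` and compound 3 `COc1cc(CNC(=O)CCCC/C=C/C(C)C)ccc1OCCCCOc1ccc(C(N)=S)cc1` share one core, while compound 2 `COc1cc(CNC(=O)CCCCCCC(C)C)ccc1OC(=O)CCC(=O)Oc1ccc(-c2cc(=S)ss2)cc1` and the unmeasured compound 4 `COc1cc(CNC(=O)CCCC/C=C/C(C)C)ccc1OC(=O)CCC(=O)Oc1ccc(-c2cc(=S)ss2)cc1` share another; the difference between the two cores is not broken down here. In a functional assay on K562 cells (Homo sapiens) for antiproliferative activity, read by MTT assay, with a stated time of 48 h (a higher number here means a weaker inhibitor, a lower number a stronger inhibitor), compound 1 gives > 50000 nM, which is a limit of the assay and not a number. Compound 3 likewise gives > 50000 nM in this assay, again a limit rather than a number. Going by the values given here, compound 2 gives 5930 nM in this assay, the only number among the three measured values.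

The change from compound 1 to compound 3 is 3-methylbut-1-en-1-yl in place of isopentyl on a saturated chain carbon, four bonds along the chain from a carbonyl carbon, and the step it made, a step that the two limits leave unreadable from compound 1 to compound 3, cannot be read as a size, because of the limit of > 50000 nM in this assay, at which 2 of the 3 values shown sit. The same change is made on the other core, as 3-methylbut-1-en-1-yl in place of isopentyl on a saturated chain carbon, four bonds along the chain from a carbonyl carbon. Since the measured instance of this change gives no readable step, the expectation for compound 4 rests on the measured value of compound 2, 5930 nM, with the step of a 1.0-fold higher number from compound 2 to compound 4 (0.01 log units; within the scatter) expected to stay small. Compound 4 is therefore estimated at 6000 nM in this assay, between 2500 nM and 15000 nM.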

Compound 4, half-maximal inhibitory concentration: 4450 nM
The estimate for compound 4 lay 1.3-fold (0.13 log units) above the measured number; the range from low to high includes it.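

Placing 3-methylbut-1-en-1-yl where isopentyl stood gives, in this assay, a 1.3-fold lower number from compound 2 to compound 4 (0.12 log units; within the scatter), so on this core the change makes no readable difference to the antiproliferative read-out. This result cannot be set against the same change on the other core, because compound 1 and compound 3 both sit at a limit of the assay and not at a number: the limit of > 50000 nM in this assay, at which 2 of the 4 values shown sit. The series therefore holds a single readable instance of the change, which shows that it leaves the value within the scatter on one core, but does not show that this behaviour carries over from one core to the other.

The compounds shown leave open whether a longer chain, or a carboxylic acid in place of isopentyl, would move the value on either core. They also leave open how the difference between the two cores divides among its parts, as the linker and the group at its far end change together.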